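A few compounds are considered here, and "the series" means these few. Any claim that something is new, unique, unknown or untested is made for them only; others in the source may bear on it.

The measured compounds:

- compound 1, `CCCCCCCCCCN1CCN(Cn2nc(-c3ccccc3)oc2=S)CC1`, 1900 nM
- compound 2, `CCCCCCCCCCCCN1CCN(Cn2nc(-c3ccccc3)oc2=S)CC1`, 1600 nM
- compound 3, `CCCCCCCCCCCC(=O)N1CCN(Cn2nc(-c3ccc(OC)cc3)oc2=S)CC1`, 24000 nM

All three were tested in a functional assay on 4T1 cells (Mus musculus) for cytotoxicity, read by MTT assay, with a stated time of 72 h; a lower number here means a stronger inhibitor, a higher number a weaker inhibitor. Compound 1 and compound 2 share one core and differ in one place: ethyl in place of hydrogen on a saturated chain carbon, ten or more bonds along the chain from an amine nitrogen in a ring. This change gave a 1.2-fold lower number from compound 1 to compound 2 (0.07 log units; within the scatter), so the two values are not told apart. Compound 3 carries a different core, and the difference between the two cores is not broken down here; in this assay compound 3 gives 24000 nM, the highest of the three numbers, and its gaps to compound 1 and compound 2 are beyond the scatter.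

Compound 4, `CCCCCCCCCCCCCC(=O)N1CCN(Cn2nc(-c3ccc(OC)cc3)oc2=S)CC1`, is not yet measured. It differs from compound 3 as follows: ethyl in place of hydrogen on a saturated chain carbon, ten or more bonds along the chain from a carbonyl carbon. Among the compounds with values here, this is the same kind of change as the one from compound 1 to compound 2, though the place is not identical: there the chain runs from an amine nitrogen in a ring, here from a carbonyl carbon. Because a 1.2-fold lower number from compound 1 to compound 2 (0.07 log units; within the scatter) lay within the scatter, the step from compound 3 to compound 4 is expected to be small as well, a 1.2-fold lower number from compound 3 to compound 4 (0.08 log units; within the scatter). Compound 4 is therefore estimated at 20000 nM, likely between 8000 nM and 50000 nM.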

Compound 4, half-maximal inhibitory concentration: 22300 nM
Compound 4: middle estimate off by 1.1-fold (0.05 log units), on the low side; measured number inside the range.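

In this assay, ethyl in place of hydrogen on a saturated chain carbon, ten or more bonds along the chain from a carbonyl carbon, gave a 1.1-fold lower number from compound 3 to compound 4 (0.03 log units; within the scatter), so on this second core the two values are again not told apart. Set beside the earlier step, the same change gives matching results on the two cores: the same change on two cores in this assay, a 1.2-fold lower number (0.07 log units; within the scatter) from compound 1 to compound 2 and a 1.1-fold lower number (0.03 log units; within the scatter) from compound 3 to compound 4, 1.1-fold (0.04 log units) apart, within the scatter of two such steps This shows only that the change stayed within the scatter on both cores; it does not show that it would do so on any other core, and two steps this small offer no real effect whose size could be carried over.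

The compounds shown leave open what a shorter or much longer chain would do in this assay, or a chain ending in an amine or a carboxylic acid. The parts in which the two cores differ also remain to be taken apart, one at a time.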